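Dimethoxyphenyl in place of phenyl: expected change in cytotoxicity

The source may report more compounds than this note shows. Statements on the series, on what has been measured and on what is new or still open speak of the compounds shown alone.

Compound 1 `NS(=O)(=O)c1ccc(N2N=C(c3ccc(Cl)cc3)CC2c2cn(-c3ccccc3)nc2-c2ccccc2)cc1` gives > 206000 nM in an ADME assay on Vero cells (Chlorocebus sabaeus) for cytotoxicity, read by MTT assay, with a stated time of 72 h (a higher number here means that more compound is tolerated, a lower number that less compound is tolerated), which is a limit of the assay and not a number.
Compound 2 `COc1ccc(C2=NN(c3ccc(S(N)(=O)=O)cc3)C(c3cn(-c4ccccc4)nc3-c3ccccc3)C2)cc1` gives 40200 nM in this assay.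
Compound 3 `Cc1ccc(-c2nn(-c3ccccc3)cc2C2CC(c3ccccc3)=NN2c2ccc(S(N)(=O)=O)cc2)cc1` gives > 161000 nM in this assay, again a limit and not a number.

Compound 3 therefore stands at a limit, and so does compound 1; the two limits are the limit of > 161000 nM in this assay, at which 1 of the 3 values shown sits, and (the limit of > 206000 nM in this assay, at which 1 of the 3 values shown sits). Compound 2 is the only one of the three with a measured number.

Compound 4 `COc1cccc(C2=NN(c3ccc(S(N)(=O)=O)cc3)C(c3cn(-c4ccccc4)nc3-c3ccc(C)cc3)C2)c1OC` differs from compound 3 by 2,3-dimethoxyphenyl in place of phenyl on a carbon with a double bond to nitrogen. Among the measured compounds shown here, the one measured step that bears on this is an at least 5.1-fold lower number from compound 1 to compound 2 (0.70 log units; beyond the scatter), where a methoxy entering an aromatic ring carried the value from a limit down to a measured number. The entering group in compound 4 is also a methoxy-bearing phenyl, so a step in the same direction is expected, and the number for compound 4 is estimated to fall below the limit at which compound 3 sits: an at least 3.2-fold lower number from compound 3 to compound 4 (0.50 log units; beyond the scatter). The expected value for compound 4 is 50000 nM, with a likely range from 15000 nM to 180000 nM, though a fresh limit rather than a number remains possible.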

Compound 4, half-maximal cytotoxic concentration: > 57300 nM
Compound 4 gave a limit, no number (the forecaster's own chance of this, stated with the estimate: 30%); at least 1.1-fold (0.05 log units) between middle value and limit.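

Compound 3 and compound 4 both stand at limits of this assay and not at numbers, so the step between these two compounds cannot be read. The compounds shown leave open whether 2,3-dimethoxyphenyl in place of phenyl changes how much compound is tolerated in this assay at all, and in which direction.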